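Notes on the step from methoxycarbonyl to ethoxycarbonyl

The source may hold more compounds than are shown below. What is called first, only, known or untested is meant among the compounds shown, and "the series" means these compounds.

In an ADME assay on MT4 cells (Homo sapiens) for cytotoxicity, read by MTT assay, with a stated time of 5 days (a higher number here means that more compound is tolerated, a lower number that less compound is tolerated), compound 1 `Cc1ccc(NC(=O)CSc2ncnn2-c2ccc(Cl)cc2Cl)c(Br)c1` gives > 184000 nM, which is a limit of the assay and not a number. Compound 2 `O=C(CSc1ncnn1-c1ccc(Cl)cc1Cl)Nc1ccc(Cl)cc1Br` gives 189000 nM. Among the compounds with values here, compound 3 `COC(=O)c1ccc(NC(=O)CSc2ncnn2-c2ccc(Cl)cc2Cl)c(Br)c1` gives 59300 nM, the lowest number so far. Both measured steps that bring in methoxycarbonyl go downward: a 3.2-fold lower number from compound 2 to compound 3 (0.50 log units; beyond the scatter) and an at least 3.1-fold lower number from compound 1 to compound 3 (0.49 log units; beyond the scatter). Compound 4 `CCOC(=O)c1ccc(NC(=O)CSc2ncnn2-c2ccc(Cl)cc2Cl)c(Br)c1` carries methyl in place of hydrogen on a saturated chain carbon bound to an oxygen next to a carbonyl group, so methoxycarbonyl becomes ethoxycarbonyl. Within the data shown here, no measured step alters that group itself, and those two steps are only a distant guide. In this assay, the estimated step is a 1.1-fold lower number from compound 3 to compound 4 (0.06 log units; within the scatter), so none beyond the scatter is expected. The expected value for compound 4 is 52000 nM, within an estimated range of 26000 nM to 105000 nM.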

Compound 4, half-maximal cytotoxic concentration: 33100 nM
Compound 4: middle estimate off by 1.6-fold (0.20 log units), on the high side; measured number inside the range.
By their numbers in this assay, from the lowest: compounds 4 and 3 (each within the scatter of the next); then compound 2.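

In this assay, within the data shown here, the change from methoxycarbonyl to ethoxycarbonyl, the first step to alter that group itself, does not separate the two esters (a 1.8-fold lower number from compound 3 to compound 4 (0.25 log units; within the scatter)). The drop seen with methoxycarbonyl is kept with ethoxycarbonyl, against both chloro (a 5.7-fold lower number from compound 2 to compound 4 (0.76 log units; beyond the scatter)) and methyl (an at least 5.5-fold lower number from compound 1 to compound 4 (0.74 log units; beyond the scatter)). Compound 1 stands at a limit and not a number: the limit of > 184000 nM in this assay, at which 1 of the 4 values shown sits.

The compounds shown leave open how a longer chain on that oxygen, such as propyl, would read in this assay. From the compounds shown here alone, a carboxylic acid in place of the ester also remains open.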